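This account rests on a few compounds, and the source may have more. Where it says the series, first, only, none or still open, it means among the compounds named here.

Measured so far in an ADME assay on HepG2 2.2.15 cells (Homo sapiens) for cytotoxicity, read by luminescence, with a stated time of 3 days (a lower number here means that less compound is tolerated, a higher number that more compound is tolerated), are two compounds:
compound 1 (`O=C(Nc1ccc(F)c(Cl)c1)c1ccc(F)c(S(=O)(=O)N2C[C@H](O)CC[C@H](O)C2)c1`) with (25500 nM)
compound 2 (`O=C(Nc1ccc(F)c(Cl)c1)c1ccc(F)c(S(=O)(=O)N2CCCCC(O)CC2)c1`) with (24000 nM)

Compound 2 stands level with compound 1, the two numbers lying within the scatter of each other. The next structure is compound 3 (`O=C(Nc1ccc(F)c(Cl)c1)c1ccc(F)c(S(=O)(=O)N2CCOC[C@H](O)C2)c1`), which carries 6-hydroxy-1,4-oxazepan-4-yl on a sulfonyl sulfur: (a group of 8 heavy atoms (5 carbon, 1 nitrogen, 2 oxygen; one seven-membered non-aromatic ring with 2 hetero atoms) in place of a group of 9 heavy atoms (7 carbon, 1 nitrogen, 1 oxygen; one eight-membered non-aromatic ring with 1 hetero atom), on a sulfonyl sulfur). Among the compounds with values here, only one measured step bears on this change, a single pair in which the ring on that same sulfur also differs (a 1.1-fold lower number from compound 1 to compound 2 (0.03 log units; within the scatter)). That step stayed within the scatter, so no step beyond the scatter is expected in this assay here, though one pair is thin evidence. The expected step is small and has no firm direction (a 1.1-fold higher number from compound 2 to compound 3 (0.05 log units; within the scatter)). For compound 3 the estimated value is 27000 nM with an expected range from 13000 nM to 55000 nM in this assay.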

Compound 3, half-maximal cytotoxic concentration: 19000 nM
Estimate against measurement, compound 3: 1.4-fold (0.15 log units) above; the range from low to high includes it.
By their numbers in this assay, from the lowest: compounds 3, 2 and 1 (each within the scatter of the next).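

In this assay, 6-hydroxy-1,4-oxazepan-4-yl on the sulfonyl sulfur gives a 1.3-fold lower number from compound 2 to compound 3 (0.10 log units; within the scatter) and, set against 3,6-dihydroxyazepan-1-yl, a 1.3-fold lower number from compound 1 to compound 3 (0.13 log units; within the scatter) in the same place. All three compounds therefore lie within the scatter of one another, and this position has still shown no step beyond the scatter, now also with a seven-membered ring holding 2 hetero atoms. No measurement at hand explains why the numbers stay so close.

Still open, going by these compounds, is whether a ring carrying an amine or a carboxylic acid instead of the hydroxyl, or an open-chain alkyl amine on the sulfonyl sulfur, would give a number beyond the scatter. The three compounds also share one core, so they say nothing about changes elsewhere in it.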